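Working notes: vinyl in place of hydrogen on the shared core

This account rests on a few compounds, and the source may have more. Where it says the series, first, only, none or still open, it means among the compounds named here.

Compound 3 `c1ccc2[se]cnc2c1` sits at a limit of a functional assay on NCI-H522 cells (Homo sapiens) for cytotoxicity, with a stated time of 3 days; a higher number here means a weaker inhibitor, a lower number a stronger inhibitor: compound 3 gives > 40000 nM, which is a limit of the assay and not a number. Compound 1 `Ic1nc2ccccc2[se]1`, with iodo on the same core, also gives only a limit, > 40000 nM. The step that the two limits leave unreadable from compound 1 to compound 3 therefore cannot be read, since (the limit of > 40000 nM in this assay, at which 2 of the 3 values shown sit). Within the data shown here, compound 2 `C#Cc1sc(-c2ccc(F)cc2)nc1C(=O)OCC`, on a different core, holds the only numbered value; in this assay compound 2 gives 3530 nM. Compound 4 `C=Cc1nc2ccccc2[se]1` carries vinyl in place of hydrogen on an aromatic carbon. Among the measured compounds shown here, no measured step bears directly on this change; the only step on the shared core is unreadable. The expected step of a number no higher from compound 3 to compound 4 (the limit leaves the size open) is none beyond the scatter, with compound 4 most likely again at the limit. For compound 4 the estimate in this assay is 40000 nM, within a range of 10000 nM to 100000 nM.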

Compound 4, half-maximal inhibitory concentration: 12200 nM
The estimate for compound 4 lay 3.3-fold (0.52 log units) above the measured number, within the range that was stated.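

In this assay the shared core gives its first readable steps at this aromatic carbon next to the ring nitrogen and next to the ring selenium: an at least 3.2-fold lower number from compound 3 to compound 4 (0.51 log units; beyond the scatter) with vinyl in place of hydrogen and an at least 3.2-fold lower number from compound 1 to compound 4 (0.51 log units; beyond the scatter) with vinyl in place of iodo. Vinyl thus lowers the number at this position, whereas hydrogen and iodo could not be told apart. Both sizes remain open-ended, each step starting from a limit of the assay: the limit of > 40000 nM in this assay, at which 2 of the 4 values shown sit.

Open, going by these compounds, is whether an ethyl group, a longer chain or an amine at this carbon would give a step of similar size.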